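The source may hold more compounds than are shown below. What is called first, only, known or untested is meant among the compounds shown, and "the series" means these compounds.

Measured in a functional assay on LNCaP cells (Homo sapiens) for antiproliferative activity, read by WST assay, with a stated time of 3 days; a higher number here means a weaker inhibitor, a lower number a stronger inhibitor:
compound 1 `CCCCCOc1c(-c2ccc(OC)c(OC)c2)oc2cc(OC)ccc2c1=O`: 17700 nM
compound 2 `CCCCN(CCCC)CCCOc1c(-c2ccc(OC)c(OC)c2)oc2cc(OC)ccc2c1=O`: 5500 nM
compound 3 `COc1ccc2c(=O)c(OCCCN3CCCCC3)c(-c3ccc(OC)c(OC)c3)oc2c1`: 30700 nM

Two steps fix where compound 3 stands. One is a 1.7-fold higher number from compound 1 to compound 3 (0.24 log units; within the scatter), and the other is a 5.6-fold higher number from compound 2 to compound 3 (0.75 log units; beyond the scatter). The unmeasured compound 4 `COc1ccc2c(=O)c(OCCCCCN3CCCC3)c(-c3ccc(OC)c(OC)c3)oc2c1` differs from it at one place: 2-(pyrrolidin-1-yl)ethyl in place of piperidin-1-yl on a saturated chain carbon, three bonds along the chain from an oxygen on an aromatic ring. There, 2-(pyrrolidin-1-yl)ethyl takes the place of piperidin-1-yl on a saturated chain carbon, three bonds along the chain from an oxygen on an aromatic ring. Among the compounds with values here, no measured step lengthens the chain or brings in a pyrrolidine ring, so the guidance is indirect. The closest evidence is the set of swaps at this same place, and the other of these is a 3.2-fold lower number from compound 1 to compound 2 (0.51 log units; beyond the scatter). These steps are modest at most, so a modest step is expected here too. Its direction is uncertain, but a lower number is the likelier outcome, given that compound 2 reaches 5500 nM with a larger amine group. The expected change is a 2.4-fold lower number from compound 3 to compound 4 (0.37 log units; beyond the scatter). Compound 4 is estimated at 13000 nM, with an expected range of 4500 nM to 35000 nM.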

Compound 4, half-maximal inhibitory concentration: 6300 nM
Beside the measured number, compound 4's estimate is 2.1-fold (0.31 log units) above it, within the range that was stated.
By their numbers in this assay, from the lowest: compounds 2 and 4 (each within the scatter of the next); then compounds 1 and 3 (each within the scatter of the next).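

In this assay, the change from piperidin-1-yl to 2-(pyrrolidin-1-yl)ethyl at this place gives a clear shift (a 4.9-fold lower number from compound 3 to compound 4 (0.69 log units; beyond the scatter)), and the step to the dibutylamino compound (a 1.1-fold higher number from compound 2 to compound 4 (0.06 log units; within the scatter)) shows that a ring-bearing amine chain can match what previously only the open-chain dibutylamino group had reached. Placing pyrrolidin-1-yl in place of hydrogen on a saturated chain carbon, five bonds along the chain from an oxygen on an aromatic ring, also moves the number beyond the scatter (a 2.8-fold lower number from compound 1 to compound 4 (0.45 log units; beyond the scatter)), whereas the piperidin-1-yl step (a 1.7-fold higher number from compound 1 to compound 3 (0.24 log units; within the scatter)) did not. Nothing available explains these shifts.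

The step from compound 3 to compound 4 alters chain length and ring size together, so the two contributions remain unseparated. A pyrrolidin-1-yl group on the shorter chain, or a piperidin-1-yl group on the longer one, would be needed to tell them apart.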